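Methyl in Place of Fluoro: What to Expect of Compound 4

The source may hold more compounds than are shown below. What is called first, only, known or untested is meant among the compounds shown, and "the series" means these compounds.

Compound 1 `O=C1O/C(=C\Cn2ncc(=O)[nH]c2=O)C(OCc2ccccc2)=C1OCc1ccccc1` gives 20400 nM in a functional assay on MIA PaCa-2 cells (Homo sapiens) for inhibition, read by MTT assay, with a stated time of 72 h; a lower number here means a stronger inhibitor, a higher number a weaker inhibitor.
Compound 2 `NC1(CCn2cc(F)c(=O)[nH]c2=O)OC(=O)C(OCc2ccccc2)=C1OCc1ccccc1` gives only > 100000 nM in this assay, which is a limit of the measurement and not a number.
Compound 3 `O=C1O[C@H]([C@@H](O)Cn2ccc(NC(=O)c3ccccc3)nc2=O)C(OCc2ccccc2)=C1OCc1ccccc1` gives only > 100000 nM in this assay, again a limit rather than a number.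

Of the three compounds measured, only compound 1 yields a real number. Compound 2 sits at the upper edge of what this assay can report, so nothing tells how far beyond that edge it lies; it shares this position with one other compound, as the limit of > 100000 nM in this assay, at which 2 of the 3 values shown sit, records. Compound 4 `Cc1cn(CCC2(N)OC(=O)C(OCc3ccccc3)=C2OCc2ccccc2)c(=O)[nH]c1=O` differs from compound 2 in a single spot: methyl in place of fluoro on an aromatic carbon. Within the data shown here, no pair of measured compounds differs in just one place, so no measured step is available to guide the change. With compound 2 already at the limit, the step from compound 2 to compound 4 is expected to be none beyond the usual scatter, and a number no higher from compound 2 to compound 4 (the limit leaves the size open) expresses that expectation. Compound 4 is therefore estimated at 100000 nM in this assay, with a plausible range from 40000 nM to 250000 nM, and a real chance that only a limit is reported again.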

Compound 4, half-maximal inhibitory concentration: > 100000 nM
Compound 4: only a limit was reported; the forecaster's own chance of this, stated with the estimate: 65%; the middle value lies on the limit itself.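

Compound 4, like compound 2, gives only a limit and not a number in this assay, so no step can be read between these two compounds. The compounds shown leave open how far past that limit each one lies, and so whether methyl in place of fluoro on an aromatic carbon changes the inhibition at all.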